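Moving the thiophene attachment on an inactive nucleoside

The source may hold more compounds than are shown below. What is called first, only, known or untested is meant among the compounds shown, and "the series" means these compounds.

Values in a functional assay on HeLa S3 cells (Homo sapiens) for antiproliferative activity, read by XTT assay, with a stated time of 72 h; on this read-out lower numbers stand for stronger inhibition and higher numbers for weaker inhibition:
Compound 1 `CSc1ncnc2c1c(-c1ccsc1)cn2[C@@H]1O[C@H](CO)[C@@H](O)[C@H]1O`: > 20000 nM, a limit.
Compound 2 `Nc1nc(N)c2c(-c3ccco3)cn([C@@H]3O[C@H](CO)[C@@H](O)[C@H]3O)c2n1`: > 20000 nM, a limit.
Compound 3 `Nc1nc(N)c2c(-c3cccs3)cn([C@@H]3O[C@H](CO)[C@@H](O)[C@H]3O)c2n1`: > 20000 nM, a limit.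

Compound 3 stands at the limit of > 20000 nM in this assay, at which 3 of the 3 values shown sit, so it offers no number to start from, only a limit. Compound 4 `Nc1nc(N)c2c(-c3ccsc3)cn([C@@H]3O[C@H](CO)[C@@H](O)[C@H]3O)c2n1` has not yet been measured in this assay. It differs from compound 3 as follows: thiophen-3-yl in place of thiophen-2-yl on an aromatic carbon. Thiophen-3-yl thus takes the place of thiophen-2-yl on an aromatic carbon, and the two structures hold the same atoms.

The closest measured change is a step that the two limits leave unreadable from compound 2 to compound 3, which swaps one five-membered aromatic ring for another, and its size cannot be read. Compound 1 also bears thiophen-3-yl, and compound 1 gives > 20000 nM, again a limit. Within the data shown here, no measured step therefore points to a gain or a loss, and no change beyond the scatter is expected. The expected step is a number no higher from compound 3 to compound 4 (the limit leaves the size open). The estimate for compound 4 is 20000 nM, with an expected range from 8000 nM to 30000 nM.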

Compound 4, half-maximal inhibitory concentration: > 20000 nM
Compound 4: a limit, no number (the forecaster's own chance of this, stated with the estimate: 85%); the middle value lies on the limit itself.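

Compound 4 gives only a limit, and the steps among compound 2, compound 3 and compound 4 cannot be read: the limit of > 20000 nM in this assay, at which 4 of the 4 values shown sit. The compounds shown leave open whether thiophen-2-yl and thiophen-3-yl differ at all in this assay.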